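This account rests on a few compounds, and the source may have more. Where it says the series, first, only, none or still open, it means among the compounds named here.

Working notes on the series.

Of the compounds shown here, three in this set have been measured. Compound 1 `O=C(NCCCCc1ccc2ccccc2c1)n1c(=O)oc2ccccc21` gives 71 nM in an assay on HEK293 cells for inhibition of acid ceramidase (Homo sapiens), with a stated time of 10 min; on this read-out higher numbers stand for weaker inhibition and lower numbers for stronger inhibition. Compound 2 `O=C(NCCCCc1ccccc1)n1c(=O)oc2ccc([N+](=O)[O-])cc21`, which carries a nitro group on the shared core and a plain phenyl at the chain end, gives 3 nM in this assay. Compound 3 `COc1ccc(CCCCNC(=O)n2c(=O)oc3ccccc32)cc1` gives 63 nM in this assay. Compound 3 stands second highest of the three numbers: its nearest neighbour is compound 1, whose number is within the scatter, and its furthest is compound 2, whose number is lower by a margin beyond the scatter.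

Compound 4 `O=C(NCCCCc1cccs1)n1c(=O)oc2ccccc21` has not yet been measured. The change from compound 3 to compound 4 is thiophen-2-yl in place of 4-methoxyphenyl on a saturated chain carbon, four bonds along the chain from an amide-type nitrogen. Compound 1 and compound 3, which differ only in the terminal aromatic group, give numbers within the scatter of each other, so swapping the terminal aromatic group on the unsubstituted core has so far not shifted the read-out. Within the data shown here, no measured pair shows the step to a five-membered aromatic ring at this position, so the direction is open; the expected step from compound 3 to compound 4 is a 1.4-fold higher number from compound 3 to compound 4 (0.15 log units; within the scatter), a small move toward a higher number that may well lie within the scatter. Compound 4 is therefore estimated at 90 nM in this assay, within a range from 35 nM to 250 nM.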

Compound 4, half-maximal inhibitory concentration: 37 nM
Beside the measured number, compound 4's estimate is 2.4-fold (0.39 log units) above it; low and high end bracket the measured number.
By their numbers in this assay, from the lowest: compound 2; then compounds 4, 3 and 1 (each within the scatter of the next).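

In this assay the change to thiophen-2-yl in place of 4-methoxyphenyl on a saturated chain carbon, four bonds along the chain from an amide-type nitrogen, gives a 1.7-fold lower number from compound 3 to compound 4 (0.23 log units; within the scatter) and so stays inside the usual scatter. Among these compounds, this is the first measured pair to show that a five-membered aromatic ring with 1 hetero atom can stand at this position in place of a six-membered aromatic ring of carbon only without a shift beyond the scatter, even though the terminal group goes from 8 heavy atoms to 5. No supporting measurement bears on why the read-out holds across this change.

The compounds shown leave open whether a terminal group of another kind, such as a pyridine ring, an amine or a carboxylic acid, or a longer chain, would also keep the number within the scatter. Among the compounds shown here, compound 2 carries a nitro group on the shared core, but no pair here isolates that group, so its effect alongside thiophen-2-yl at the chain end remains unknown.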